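The source may hold more compounds than are shown below. What is called first, only, known or untested is meant among the compounds shown, and "the series" means these compounds.

Three compounds have so far been tested in an assay on blood for inhibition of Polyunsaturated fatty acid 5-lipoxygenase (Homo sapiens), tested at 10 uM; on this read-out higher numbers stand for a stronger effect at the one concentration tested and lower numbers for a weaker effect:

Compound 1, `O=C1OC(c2ccccc2)C(c2ccc(O)cc2)=C1O`: 0%
Compound 2, `O=C1OC(c2ccc(F)cc2)C(c2ccc(O)cc2)=C1O`: 0%
Compound 3, `O=C1OC(c2ccc(OCc3ccccc3)cc2)C(c2ccc(O)cc2)=C1O`: 0%

Compound 3 stands level with the other two: the step of no change at the digits printed from compound 1 to compound 3 (within the scatter) and the step of no change at the digits printed from compound 2 to compound 3 (within the scatter) both show nothing beyond the scatter, as does the step of no change at the digits printed from compound 1 to compound 2 (within the scatter). All three share one core and differ only on one of the two phenyl rings, and none of them shows measurable inhibition at the concentration tested.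

Compound 4, `O=C1OC(c2ccc(OCc3ccccc3)cc2)C(c2ccc(F)cc2)=C1O`, has not yet been measured. It differs from compound 3 in the other phenyl ring: fluoro in place of hydroxy on an aromatic carbon, on an aromatic carbon of a six-membered aromatic ring of carbon only, para to a large group. Among the compounds with values here, no measured step touches this ring, so nothing in the data bears directly on the exchange of hydroxy for fluoro. What the data do show is that three variations elsewhere on the core all left the read-out at the floor. With every measured value at zero and no step beyond the scatter, the step of no change at the digits printed from compound 3 to compound 4 (within the scatter) is expected to be no change beyond the scatter. Compound 4 is therefore estimated at 0%, within a range from 0% to 10%.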

Compound 4, a percentage reported as activity, at one concentration (the size of the read-out at that concentration, not a potency): 0%
Estimate against measurement, compound 4: no gap at the digits printed; low and high end bracket the measured number.
By their numbers in this assay, from the lowest: compounds 1, 2, 3 and 4 (each within the scatter of the next).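

In this assay, within the data shown here, the exchange of 4-hydroxyphenyl for 4-fluorophenyl gives no change at the digits printed from compound 3 to compound 4 (within the scatter), and this is the first measured step on this second phenyl ring, since the earlier steps all lay on the other one. It shows that the hydroxy group, with its hydrogen-bond donor and acceptor, is not enough on its own to give a measurable reading in this series, yet it says little about the role of that group: compound 3 already reads 0%, so any loss from removing the hydroxy could not be seen. Nothing available explains this result.

Going by these compounds, whether the hydroxy group matters in a compound of this series that does show inhibition remains unknown, as all four compounds read the same. Also open is whether an amine or a carboxylic acid on this ring, or a longer chain in place of the benzyloxy group, would lift the read-out above the level of these compounds.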